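From Fluoro to Chloro: Estimating Compound 3

The source may report more compounds than this note shows. Statements on the series, on what has been measured and on what is new or still open speak of the compounds shown alone.

In an assay on C6 glioma cells for displacement of a labelled ligand from sodium- and chloride-dependent glycine transporter 1 (Rattus norvegicus), read by scintillation counting, with stated times of 30 min and 10 min (a lower number here means a stronger inhibitor, a higher number a weaker inhibitor), two compounds have been measured:
compound 1 `CCc1nnc(-c2ccc(-c3ccccc3)cc2)n1-c1cccc(COC)c1C` gives 2400 nM
compound 2 `CCc1nnc(-c2ccc(-c3ccccc3)cc2)n1-c1cccc(F)c1C` gives 630 nM

Among the compounds with values here, compound 2 stands lowest of the two numbers, and its only neighbour is compound 1; the single measured step runs between them: a 3.8-fold lower number from compound 1 to compound 2 (0.58 log units; beyond the scatter). Compound 3 `CCc1nnc(-c2ccc(-c3ccccc3)cc2)n1-c1cccc(Cl)c1C` has not been measured. It differs from compound 2 by chloro in place of fluoro on an aromatic carbon. Within the data shown here, the one measured step touches the same carbon and shows that exchanging the group there moves the number by a modest amount, but nothing measured separates fluoro from chloro directly. The step is therefore expected to be small, a 1.3-fold lower number from compound 2 to compound 3 (0.10 log units; within the scatter), likely within the scatter. Compound 3 is estimated at 500 nM in this assay, with a range from 150 nM to 1600 nM.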

Compound 3, half-maximal inhibitory concentration: 2200 nM
Beside the measured number, compound 3's estimate is 4.4-fold (0.64 log units) below it, and the stated range ends below it.
By their numbers in this assay, from the lowest: compound 2; then compounds 3 and 1 (each within the scatter of the next).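

In this assay this aromatic carbon turns out to respond to a change as small as one halogen for another: chloro in place of fluoro gives a 3.5-fold higher number from compound 2 to compound 3 (0.54 log units; beyond the scatter) and so the 3-chloro-2-methylphenyl compound does not keep the low number of its 3-fluoro-2-methylphenyl counterpart. Chloro in place of methoxymethyl gives a 1.1-fold lower number from compound 1 to compound 3 (0.04 log units; within the scatter) and these two groups cannot be told apart here, which leaves fluoro as the only one of the three groups that stands clear of the others. Nothing at hand accounts for this difference between the two halogens. The compounds shown leave open how bromo, a hydroxyl, an amine or a longer chain would read at this carbon. They also leave open whether fluoro keeps its lead over chloro without the methyl group.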